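The source may hold more compounds than are shown below. What is called first, only, known or untested is meant among the compounds shown, and "the series" means these compounds.

Measured in an assay on RAW264.7 cells for antagonist activity at Toll-like receptor 2 (Mus musculus), read by Griess assay, with a stated time of 24 h; a lower number here means a stronger inhibitor, a higher number a weaker inhibitor:
compound 1 `C=CCCSC[C@H](NC(=O)c1cc(O)c(O)c(O)c1)C(=O)OC` gives 57800 nM
compound 2 `C=CCSC[C@H](NC(=O)c1cc(O)cc(O)c1)C(=O)OC` gives 58500 nM
compound 3 `C=CCCSC[C@H](NC(=O)c1cc(O)cc(O)c1)C(=O)OC` gives 35800 nM

Compound 3 has the lowest of the three numbers, yet its separation from each neighbour is small: a 1.6-fold lower number from compound 1 to compound 3 (0.21 log units; within the scatter) and a 1.6-fold lower number from compound 2 to compound 3 (0.21 log units; within the scatter) both fall within the scatter, so no ordering among the three is established in this assay.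

Compound 4 `C#CCSC[C@H](NC(=O)c1cc(O)cc(O)c1)C(=O)OC` differs from compound 3 by ethynyl in place of allyl on a saturated chain carbon bound to a sulfur. Within the data shown here, the only measured step at that same place is a 1.6-fold lower number from compound 2 to compound 3 (0.21 log units; within the scatter), where the chain on the sulfur was lengthened from vinyl to allyl without moving the number beyond the scatter. The remaining step, a 1.6-fold lower number from compound 1 to compound 3 (0.21 log units; within the scatter), concerns an aromatic hydroxy and does not bear on the sulfur chain. Shortening the chain to ethynyl is therefore expected to leave this assay essentially unchanged, with no step beyond the scatter in either direction; the expected step is a 1.2-fold higher number from compound 3 to compound 4 (0.07 log units; within the scatter). Compound 4 is estimated at 42000 nM, with a range from 18000 nM to 95000 nM.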

Compound 4, half-maximal inhibitory concentration: 41800 nM
For compound 4 the middle estimate is 1.0-fold (0.00 log units) above the measured one; measured number inside the range.
By their numbers in this assay, from the lowest: compounds 3, 4, 1 and 2 (each within the scatter of the next).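

In this assay, ethynyl now joins vinyl and allyl on a saturated chain carbon bound to a sulfur: a 1.2-fold higher number from compound 3 to compound 4 (0.07 log units; within the scatter) and a 1.4-fold lower number from compound 2 to compound 4 (0.15 log units; within the scatter) are the two new readings at this place. Together with the earlier step between compound 2 and compound 3, they leave all three chains within the scatter of one another, so exchanging a double bond for a triple bond outside the aromatic ring gives no detectable change here. No accompanying measurement bears on this result.

On these data alone, whether an amine, a carboxylic acid or a longer chain such as hexyl in place of ethynyl would move the number beyond the scatter remains open. Also open, as far as these compounds go, is whether ethynyl would read the same on the core of compound 1, with its additional aromatic hydroxy.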